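A Small Amine at the Open Position of Compound 3

The source may hold more compounds than are shown below. What is called first, only, known or untested is meant among the compounds shown, and "the series" means these compounds.

Compound 3 `Cc1noc(NS(=O)(=O)c2cccc3ccccc23)c1C` is the weakest of the three measured compounds: in an assay on VSM-A10 cells for antagonist activity at Endothelin-1 receptor (Rattus norvegicus) (on this read-out higher numbers stand for weaker inhibition and lower numbers for stronger inhibition), compound 3 gives 20000 nM, the highest number of the set. Its nearest neighbour is compound 2 `Cc1noc(NS(=O)(=O)c2cccc3c(CN(C)C)cccc23)c1C`, which in this assay gives 2800 nM; the step of a 7.1-fold higher number from compound 2 to compound 3 (0.85 log units; beyond the scatter) is modest but clearly beyond the scatter. Furthest away is compound 1 `Cc1noc(NS(=O)(=O)c2cccc3c(N4CCCCC4=O)cccc23)c1C`, which gives 270 nM; the step of a 74-fold higher number from compound 1 to compound 3 (1.87 log units; beyond the scatter) is large. Between those two substituted compounds the step of a 10-fold higher number from compound 1 to compound 2 (1.02 log units; beyond the scatter) is also large.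

Compound 4 `CNc1cccc2c(S(=O)(=O)Nc3onc(C)c3C)cccc12` differs from compound 3 by methylamino in place of hydrogen on an aromatic carbon. Both measured steps that bear on this change, a 7.1-fold higher number from compound 2 to compound 3 (0.85 log units; beyond the scatter) and a 74-fold higher number from compound 1 to compound 3 (1.87 log units; beyond the scatter), show that filling this position with a substituent gives a lower number than leaving it as hydrogen, with the larger ring-bearing group giving the larger step. The methylamino group counts fewer heavy atoms than either of those substituents, so a downward step is expected, but a smaller one than the ring-bearing group produced. Compound 4 is therefore expected to give about 4000 nM in this assay, with a likely range of 1500 nM to 12000 nM. This estimate corresponds to a step of a 5.0-fold lower number from compound 3 to compound 4 (0.70 log units; beyond the scatter).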

Compound 4, half-maximal inhibitory concentration: 130 nM
Compound 4: middle estimate off by 31-fold (1.49 log units), on the high side, and the stated range ends above it.
By their numbers in this assay, from the lowest: compound 4; then compound 1; then compound 2; then compound 3.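

In this assay, methylamino, with its 2 heavy atoms and no ring, gives the largest step yet seen at this position (a 150-fold lower number from compound 3 to compound 4 (2.19 log units; beyond the scatter)), so compound 4 goes against the earlier trend in which the larger ring-bearing group gave the larger step. It also surpasses both larger substituents, by a wide margin over (dimethylamino)methyl (a 22-fold lower number from compound 2 to compound 4 (1.33 log units; beyond the scatter)) and by a modest margin, still beyond the scatter, over 2-oxopiperidin-1-yl (a 2.1-fold lower number from compound 1 to compound 4 (0.32 log units; beyond the scatter)), which makes compound 4 the strongest of the four and shows that heavy-atom count does not set the order here. The data include no measurement that would explain this result.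

The compounds shown do not separate the contribution of the nitrogen on the aromatic carbon from that of the hydrogen it carries, a question that a plain amine and a dimethylamino group at this position would address. Nor do they show how far the methylamino chain can be extended, as with ethylamino, or whether an acetamide would keep the low number of compound 4.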